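Swapping 4-Aminophenyl for 3,4-Dinitrophenyl on the Shared Core

The source may report more compounds than this note shows. Statements on the series, on what has been measured and on what is new or still open speak of the compounds shown alone.

Measured so far in a functional assay on RS4-11 cells (Homo sapiens) for inhibition, read by CCK-8 assay, with a stated time of 48 h; a lower number here means a stronger inhibitor, a higher number a weaker inhibitor

Compound 1 `O=C(NCCNS(=O)(=O)c1ccc(-c2ccccc2O[C@H]2CC[C@H](O)CC2)s1)Nc1cc(C(F)(F)F)cc(C(F)(F)F)c1` gives 10100 nM
Compound 2 `O=C(NCCNS(=O)(=O)c1ccc(-c2ccccc2OCc2cccc(O)c2)s1)Nc1cc(C(F)(F)F)cc(C(F)(F)F)c1` gives 3000 nM
Compound 3 `Nc1ccc(Oc2ccccc2-c2ccc(S(=O)(=O)NCCNC(=O)Nc3cc(C(F)(F)F)cc(C(F)(F)F)c3)s2)cc1` gives 11900 nM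

Compound 3 stands level with compound 1, and the gap between them is a 1.2-fold higher number from compound 1 to compound 3 (0.07 log units; within the scatter). Both have higher numbers than compound 2, so both are weaker inhibitors, as a 3.4-fold lower number from compound 1 to compound 2 (0.53 log units; beyond the scatter) and a 4.0-fold higher number from compound 2 to compound 3 (0.60 log units; beyond the scatter) show.

The next compound, compound 4 `O=C(NCCNS(=O)(=O)c1ccc(-c2ccccc2Oc2ccc([N+](=O)[O-])c([N+](=O)[O-])c2)s1)Nc1cc(C(F)(F)F)cc(C(F)(F)F)c1`, keeps the shared core and carries 3,4-dinitrophenyl in place of 4-aminophenyl on an oxygen on an aromatic ring. Among the measured compounds shown here, all three measured steps change the group at this same place, so they are the only guide. For the measured compounds named here, they are small to modest in size, and none of the measured compounds carries a 3,4-dinitrophenyl group, so the data give no firm direction for this swap. Compound 4 is therefore expected to fall within or near the span already seen, and only a small shift is expected, a 1.7-fold lower number from compound 3 to compound 4 (0.23 log units; within the scatter), which would not stand clear of the scatter. For compound 4 the estimated value is 7000 nM with an expected range from 2500 nM to 20000 nM.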

Compound 4, half-maximal inhibitory concentration: 2400 nM
Beside the measured number, compound 4's estimate is 2.9-fold (0.46 log units) above it; the whole stated range lies above it.
By their numbers in this assay, from the lowest: compounds 4 and 2 (each within the scatter of the next); then compounds 1 and 3 (each within the scatter of the next).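

Among the compounds shown here, replacing 4-aminophenyl with 3,4-dinitrophenyl gives a 5.0-fold lower number from compound 3 to compound 4 (0.70 log units; beyond the scatter) in this assay, the first step in this set between two groups that both place a six-membered aromatic ring of carbon only directly on the oxygen. The presence of that ring therefore does not fix the number at this position, and what the ring carries can move it beyond the scatter. The same group gives a 4.2-fold lower number from compound 1 to compound 4 (0.62 log units; beyond the scatter), whereas the step to it from 3-hydroxybenzyl is only a 1.3-fold lower number from compound 2 to compound 4 (0.10 log units; within the scatter), so two quite different groups now sit level at the low end of this small set, and nothing shown explains why.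

The change from compound 3 to compound 4 removes an amine and adds two nitro groups in a single step, so the compounds shown cannot separate the loss of the amine from the gain of either nitro group. Unsubstituted phenyl or a phenyl ring carrying a single nitro group would be needed to separate them, and how a carboxylic acid on the ring would behave remains open as well.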